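This account rests on a few compounds, and the source may have more. Where it says the series, first, only, none or still open, it means among the compounds named here.

Measured compounds and their values in a functional assay on HepG2 cells (Homo sapiens) for cytotoxicity, read by XTT assay, with a stated time of 72 h; on this read-out lower numbers stand for stronger inhibition and higher numbers for weaker inhibition:

Compound 1, `ClCc1c[se]c(N/N=C/c2ccc(Cl)cc2)n1`, gives > 75000 nM, which is a limit of the assay and not a number.
Compound 2, `ClCc1c[se]c(N/N=C/c2csc(-c3ccccc3)n2)n1`, gives 18800 nM.
Compound 3, `CC(=O)N(/N=C/c1ccc(Cl)cc1)c1nc(CCl)c[se]1`, gives > 66600 nM, which is again a limit and not a number.

Among the three, compound 2 thus supplies the only number; the other two values are limits. The change from compound 1 to compound 3 is acetyl in place of hydrogen on a nitrogen on an aromatic ring, and its size is a step that the two limits leave unreadable from compound 1 to compound 3, because the limit of > 75000 nM in this assay, at which 1 of the 3 values shown sits, and the limit of > 66600 nM in this assay, at which 1 of the 3 values shown sits, leave both ends of it unreadable. The difference between the cores of compound 1 and compound 2 is not broken down here.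

Compound 4, `CC(=O)N(/N=C/c1csc(-c2ccccc2)n1)c1nc(CCl)c[se]1`, has not yet been measured. It carries the same change relative to compound 2 as compound 3 does relative to compound 1: acetyl in place of hydrogen on a nitrogen on an aromatic ring. Since the measured step gives no readable size, the expected step in this assay is set close to no change, a 1.6-fold higher number from compound 2 to compound 4 (0.20 log units; within the scatter), with a wide range. For compound 4 the estimated value in this assay is 30000 nM, expected to fall between 10000 nM and 90000 nM.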

Compound 4, half-maximal inhibitory concentration: 19300 nM
For compound 4 the middle estimate is 1.6-fold (0.19 log units) above the measured one; measured number inside the range.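

In this assay the change of acetyl in place of hydrogen on a nitrogen on an aromatic ring gives a 1.0-fold higher number from compound 2 to compound 4 (0.01 log units; within the scatter) and so makes no readable difference on the core of compound 2. The same change on the core of compound 1 cannot be read, as compound 1 and compound 3 both stand at limits of the assay and not at numbers. Among these compounds, the series therefore shows that the acetyl is tolerated on one core, but it does not show that the change carries from one core to the other, as only one of the two steps has a size.

The compounds shown leave open how a methyl group, a propanoyl group or a benzoyl group on that same nitrogen would read in this assay on either core. They also leave open whether an amine or a carboxylic acid at that nitrogen would shift the values on the core of compound 2.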